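Sulfonyl Substituent Swap: Cyclobutyl to Cyclopropylamino

This account rests on a few compounds, and the source may have more. Where it says the series, first, only, none or still open, it means among the compounds named here.

Measured compounds:
Compound 1 `CC(C)c1noc(N2CCN(C(=O)[C@@H]3CCCN(S(=O)(=O)c4ccc(S(=O)(=O)C(C)C)cc4)C3)CC2)n1` gives 70 nM in a functional assay on MIA PaCa-2 cells (Homo sapiens) for inhibition, read by MTT assay, with a stated time of 7 days; on this read-out lower numbers stand for stronger inhibition and higher numbers for weaker inhibition.
Compound 2 `CCOC(=O)[C@@H]1C[C@H](O)CN(S(=O)(=O)c2ccc(S(=O)(=O)N(CC)CC)cc2)C1` gives 1300 nM in this assay.
Compound 3 `CC(C)c1noc(N2CCN(C(=O)[C@@H]3CCCN(S(=O)(=O)c4ccc(S(=O)(=O)C5CCC5)cc4)C3)CC2)n1` gives 70 nM in this assay.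

Compound 3 stands level with compound 1 at the digits shown, and the two together give the lowest numbers of the three. Compound 2, which differs from compound 3 in several places at once, gives a markedly higher number, so its value tells nothing direct about a single change at the sulfonyl sulfur.

Compound 4 `CC(C)c1noc(N2CCN(C(=O)[C@@H]3CCCN(S(=O)(=O)c4ccc(S(=O)(=O)NC5CC5)cc4)C3)CC2)n1` differs from compound 3 at that sulfur: cyclopropylamino in place of cyclobutyl on a sulfonyl sulfur. For the measured compounds named here, the one measured step that bears on this position, no change at the digits printed from compound 1 to compound 3 (within the scatter), shows that exchanging one small carbon group for another there left the number unchanged within the scatter. Going by the values given here, the present change also brings in a hydrogen-bond donor, for which no measured step exists, so the expectation rests on the small step from compound 1 to compound 3 alone. The account therefore expects little movement, with a modest drift towards a higher number allowed, giving a 1.4-fold higher number from compound 3 to compound 4 (0.15 log units; within the scatter). Compound 4 is estimated at 100 nM, in the range 40 nM to 300 nM.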

Compound 4, half-maximal inhibitory concentration: 1000 nM
For compound 4 the middle estimate is 10-fold (1.00 log units) below the measured one; the whole stated range lies below it.
By their numbers in this assay, from the lowest: compounds 1 and 3 (each within the scatter of the next); then compounds 4 and 2 (each within the scatter of the next).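

In this assay, for the compounds shown here, this position on the sulfonyl sulfur proves far less forgiving than the earlier compounds suggested: cyclopropylamino in place of cyclobutyl gives a 14-fold higher number from compound 3 to compound 4 (1.15 log units; beyond the scatter), and cyclopropylamino in place of isopropyl gives a 14-fold higher number from compound 1 to compound 4 (1.15 log units; beyond the scatter). The earlier step, no change at the digits printed from compound 1 to compound 3 (within the scatter), covered only an exchange between carbon groups, whereas this change keeps the count of heavy atoms the same and brings in a nitrogen and a hydrogen-bond donor, so a large step can arise here without any change in that count. No measurement shown gives a reason for this step.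

The compounds shown leave open whether the step goes with the nitrogen or with the three-membered ring. A plain cyclopropyl or a dimethylamino group on the same sulfur would separate these two.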